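Swapping methyl for fluoro on a dichloroacetamide

The compounds below may be only part of what the source reports. "The series", "measured", "known", "first", "only" and "open" are said of these compounds alone.

Measured so far in a functional assay on A549 cells (Homo sapiens) for cytotoxicity, read by MTT assay, with a stated time of 68 h (on this read-out higher numbers stand for weaker inhibition and lower numbers for stronger inhibition), are three compounds.

Compound 1 `Nc1cccc(-c2cccc(NC(=O)C(Cl)Cl)c2)c1` gives 50000 nM
Compound 2 `O=C(Nc1cccc(-c2ccccc2C(F)(F)F)c1)C(Cl)Cl` gives 7500 nM
Compound 3 `Cc1ccccc1-c1cccc(NC(=O)C(Cl)Cl)c1` gives 9860 nM

Compound 3 at 9860 nM lies within the scatter of compound 2 and beyond the scatter of compound 1, whose number is higher. The next compound keeps everything in compound 3 except one small group on a ring. Compound 4 `O=C(Nc1cccc(-c2ccccc2F)c1)C(Cl)Cl` carries fluoro in place of methyl on an aromatic carbon, ortho to a large group, and the count of that change is fluoro in place of methyl on an aromatic carbon in full.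

For the measured compounds named here, one measured step bears on this swap. Methyl in place of trifluoromethyl on an aromatic carbon gave a 1.3-fold higher number from compound 2 to compound 3 (0.12 log units; within the scatter) and so left the number almost where it was. Going by the values given here, no measured compound carries fluoro, and compound 1 is joined to the others by no measured step, so the guide is thin. Resting on a 1.3-fold higher number from compound 2 to compound 3 (0.12 log units; within the scatter) alone, a step within the scatter is expected in this assay with no firm direction. The expected step is a 1.1-fold higher number from compound 3 to compound 4 (0.05 log units; within the scatter) as estimated here. For compound 4 the estimated value is 11000 nM with an expected range from 5500 nM to 22000 nM as its span.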

Compound 4, half-maximal inhibitory concentration: 13200 nM
Beside the measured number, compound 4's estimate is 1.2-fold (0.08 log units) below it, and the stated range covers the measured number.
By their numbers in this assay, from the lowest: compounds 2, 3 and 4 (each within the scatter of the next); then compound 1.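

In this assay, the position ortho to a large group has now held three different groups, and the numbers do not separate them. Fluoro in place of methyl gives a 1.3-fold higher number from compound 3 to compound 4 (0.13 log units; within the scatter), and fluoro in place of trifluoromethyl gives a 1.8-fold higher number from compound 2 to compound 4 (0.25 log units; within the scatter). For the compounds shown here, the earlier compounds offered only a single swap here, whereas these steps, taken together with a 1.3-fold higher number from compound 2 to compound 3 (0.12 log units; within the scatter), show that no pair among the three groups differs beyond the scatter, so the choice among methyl, trifluoromethyl and fluoro at this position makes no readable difference in this cytotoxicity test. No measurement is available that could explain why the three compounds read so much alike.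

From the compounds shown here alone, what remains open is whether a group of another kind at this same position, such as a hydroxyl, a methoxy or a carboxylic acid, would shift the number beyond the scatter. Going by these compounds, it is also open how a plain hydrogen at this position would compare with these three groups, and whether fluoro would read the same elsewhere on the ring.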